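This account rests on a few compounds, and the source may have more. Where it says the series, first, only, none or still open, it means among the compounds named here.

Measured so far:
Compound 1, `O=C(Nc1ccc(Oc2ccnc3[nH]ccc23)c(F)c1)c1nn(-c2ccc(Cl)cc2)ccc1=O`: 42500 nM
Compound 2, `Cc1cc(=O)n(-c2ccc(F)cc2)nc1C(=O)Nc1ccc(Oc2ncnc3[nH]ccc23)cc1`: > 60000 nM

In a functional assay on PC-3 cells (Homo sapiens) for cytotoxicity, read by MTT assay, with a stated time of 72 h (a lower number here means a stronger inhibitor, a higher number a weaker inhibitor), compound 1 gives 42500 nM. Compound 2 reaches only the limit of this assay, > 60000 nM, so for it there is no number, just a limit (the limit of > 60000 nM in this assay, at which 1 of the 2 values shown sits). That is where compound 2 stands: at the edge of what this assay can report.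

Compound 3 is `Cc1cc(=O)n(-c2ccccc2OC(F)(F)F)nc1C(=O)Nc1ccc(Oc2ncnc3[nH]ccc23)cc1`. It differs from compound 2 in one place: 2-(trifluoromethoxy)phenyl in place of 4-fluorophenyl on an aromatic nitrogen. No measured step of this kind is shown, so its size cannot be read from the data. Neither measured compound shows strong inhibition, and a single change on the aromatic nitrogen is not expected to carry compound 3 beyond the scatter in this assay. Compound 3 is therefore expected to give about 60000 nM, between 20000 nM and 150000 nM. The step of a number no higher from compound 2 to compound 3 (the limit leaves the size open) is expected to be nothing beyond the scatter, with a real chance that only a limit is reported again.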

Compound 3, half-maximal inhibitory concentration: 22500 nM
For compound 3 the middle estimate is 2.7-fold (0.43 log units) above the measured one, within the range that was stated.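

Replacing 4-fluorophenyl with 2-(trifluoromethoxy)phenyl on the aromatic nitrogen gives an at least 2.6-fold lower number from compound 2 to compound 3 (0.42 log units; beyond the scatter) in this assay, so this position can move the result by more than the usual scatter. The gain is limited, since compound 3 still needs a high concentration (22500 nM) to reach the half-maximal effect. The step can be given only as a minimum because compound 2 has a limit and not a number: the limit of > 60000 nM in this assay, at which 1 of the 3 values shown sits.

This change alters both the substituent and its place on the phenyl ring, so the compounds shown cannot separate the two, whereas 2-fluorophenyl or 4-(trifluoromethoxy)phenyl on the same nitrogen could. Also open, as far as these compounds go, is how a phenyl ring carrying an amine or a carboxylic acid would behave in this assay at this position.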